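The compounds below may be only part of what the source reports. "The series", "measured", "known", "first", "only" and "open" are said of these compounds alone.

Measured so far:
compound 1 `Cc1nn(C)c2nc(NNC(=O)Nc3cc(Cl)nc(Cl)c3)cc(C3CC3)c12` — 3650 nM
compound 2 `COc1cc(NC(=O)NNc2cc(-c3ccc(F)cc3)c3cnn(C)c3n2)cc(OC)c1OC` — 4440 nM
compound 3 `CCN(CC)c1cc(NC(=O)NNc2cc(-c3ccc(F)cc3)c3cnn(C)c3n2)cc(Cl)n1` — 3150 nM

The three compounds share a core and were all tested in an assay on isolated protein for binding affinity to sphingosine 1-phosphate receptor 2 (Homo sapiens), read by surface plasmon resonance; a higher number here means weaker binding, a lower number tighter binding. Their numbers sit close together: compound 1 falls between compound 3 and compound 2, and the gap to either of them lies within the usual scatter of this assay, so the three cannot be told apart on these data.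

Compound 4 `Cc1nn(C)c2nc(NNC(=O)Nc3cc(Cl)nc(Cl)c3)cc(-c3ccco3)c12` differs from compound 1 in one place: furan-2-yl in place of cyclopropyl on an aromatic carbon. For the measured compounds named here, no pair among the measured compounds shows what such a change does in this assay, so there is no directly comparable step to lean on. Since the measured numbers all lie in a narrow band, the working expectation is a step from compound 1 to compound 4 of a 1.0-fold lower number from compound 1 to compound 4 (0.02 log units; within the scatter), that is, nothing beyond the scatter in either direction. Compound 4 is accordingly estimated at 3500 nM in this assay, with a plausible range from 1500 nM to 8000 nM.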

Compound 4, dissociation constant: 6520 nM
Compound 4: middle estimate off by 1.9-fold (0.27 log units), on the low side, within the range that was stated.
By their numbers in this assay, from the lowest: compounds 3, 1, 2 and 4 (each within the scatter of the next, the first and the last beyond it).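

In this assay, for the compounds shown here, putting furan-2-yl in place of cyclopropyl on the aromatic carbon opposite the ring nitrogen gives a 1.8-fold higher number from compound 1 to compound 4 (0.25 log units; within the scatter) and this is the first step here that changes one place only. A five-membered aromatic ring carrying a hydrogen-bond acceptor can thus replace a three-membered carbon ring at this position, with two more heavy atoms, and the two compounds still cannot be told apart on these data. No measurement at hand explains the size of this step.

Going by these compounds, whether an amine, a carboxylic acid or a longer alkyl chain on this same carbon would give a step beyond the scatter remains open. Also open, on these data alone, is whether the same swap gives a similar step when the dichloropyridine part of compound 1 is replaced by another group.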